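Swapping the thiophene for a furan in a tolerated series

The source may report more compounds than this note shows. Statements on the series, on what has been measured and on what is new or still open speak of the compounds shown alone.

Measured so far in an ADME assay on THP-1 cells (Homo sapiens) for cytotoxicity; a lower number here means that less compound is tolerated, a higher number that more compound is tolerated:
compound 1 `Cc1ccsc1[C@@H]1C[C@H](O)Cc2ccccc2N1` gives 579000 nM
compound 2 `Cc1ccsc1[C@@H]1C[C@H](O)Cc2cc(F)ccc2N1` gives 1810000 nM
compound 3 `Cc1ccsc1[C@@H]1C[C@H](O)Cc2cc(OC(F)(F)F)ccc2N1` gives 89700 nM

Compound 2 shows the highest number of the three in this assay: its step from compound 1 is a 3.1-fold higher number from compound 1 to compound 2 (0.50 log units; beyond the scatter), and compound 3 lies furthest away, a 20-fold lower number from compound 2 to compound 3 (1.30 log units; beyond the scatter). Compound 4 `Cc1ccc([C@@H]2C[C@H](O)Cc3cc(F)ccc3N2)o1` keeps the fluoro of compound 2 and changes only the five-membered ring attached to the seven-membered ring: 5-methylfuran-2-yl in place of 3-methylthiophen-2-yl on a saturated ring carbon. Both groups contain one five-membered aromatic ring with one hetero atom, one hydrogen-bond acceptor and no donor.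

For the measured compounds named here, none of the measured steps touches this group; all three — a 3.1-fold higher number from compound 1 to compound 2 (0.50 log units; beyond the scatter), a 6.5-fold lower number from compound 1 to compound 3 (0.81 log units; beyond the scatter) and a 20-fold lower number from compound 2 to compound 3 (1.30 log units; beyond the scatter) — move substituents on the aromatic carbon of the fused core. Going by the values given here, the only guide is that like-for-like swaps of small heteroaryl rings usually shift cytotoxicity little. Compound 4 is therefore expected to stay close to compound 2, with a 1.2-fold lower number from compound 2 to compound 4 (0.08 log units; within the scatter), and its estimated value in this assay is 1500000 nM, ranging from 600000 nM to 3500000 nM.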

Compound 4, half-maximal cytotoxic concentration: > 1140000 nM
Compound 4 ended at the assay's limit; the forecaster's own chance of this, stated with the estimate: 30%; the middle value is on the limit's open side.
By their numbers in this assay, from the lowest: compound 3; then compound 1; then compound 2.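

In this assay compound 4 gives > 1140000 nM, which is a limit of the assay and not a number. For the compounds shown here, no step between compound 2 and compound 4 can be read. The compounds shown leave open whether 5-methylfuran-2-yl in place of 3-methylthiophen-2-yl changes the number in this assay.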